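Series notes: N-substituent swap on the shared core

This account rests on a few compounds, and the source may have more. Where it says the series, first, only, none or still open, it means among the compounds named here.

Measured so far:
- compound 1, `CCCC(C)n1c(CC)nc2c(-c3ccc(/C(C)=N\OC)cc3Cl)ccnc21`: 2.3 nM
- compound 2, `CCc1nc2c(-c3ccc(C(F)(F)F)cc3Cl)ccnc2n1C(CC)CCOC`: 0.7 nM

In an assay for binding affinity to Corticotropin releasing factor receptor (Rattus norvegicus) (on this read-out lower numbers stand for stronger inhibition and higher numbers for weaker inhibition), compound 2 gives 0.7 nM, the lowest of the two numbers; compound 1 gives 2.3 nM, a higher number beyond the scatter, but the two differ in more than one place. Compound 3, `CCCC(C)n1c(CC)nc2c(-c3ccc(C(F)(F)F)cc3Cl)ccnc21`, is not yet measured. The change from compound 2 is 1-methylbutyl in place of 1-(2-methoxyethyl)propyl on an aromatic nitrogen. Within the data shown here, with no single-change step in hand, a modest rise in this assay is expected, likely at or near the scatter: the step of a 2.0-fold higher number from compound 2 to compound 3 (0.30 log units; within the scatter) is the estimate. Compound 3 is expected at 1.4 nM, range 0.5 nM to 4 nM.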

Compound 3, inhibition constant: 1.1 nM
For compound 3 the middle estimate is 1.3-fold (0.10 log units) above the measured one; the range from low to high includes it.
By their numbers in this assay, from the lowest: compounds 2 and 3 (each within the scatter of the next); then compound 1.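

In this assay the change to 1-methylbutyl in place of 1-(2-methoxyethyl)propyl on the aromatic nitrogen stays within the scatter (a 1.6-fold higher number from compound 2 to compound 3 (0.20 log units; within the scatter)), so this read-out does not tell the chain with oxygen from the all-carbon chain at this position. Compound 3 also gives a one-place reading on the aromatic carbon, where trifluoromethyl in place of the group of 5 heavy atoms gives a modest step (a 2.1-fold lower number from compound 1 to compound 3 (0.32 log units; beyond the scatter)). Nothing available gives a reason for either step.

From the compounds shown here alone, it remains open how an amine or a carboxylic acid on the chain at the aromatic nitrogen would read here. Going by these compounds, how a longer chain at that nitrogen would read also remains open.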